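This account rests on a few compounds, and the source may have more. Where it says the series, first, only, none or still open, it means among the compounds named here.

Working notes on the series. In a functional assay on HeLa cells (Homo sapiens) for cytotoxicity, read by WST assay, with a stated time of 48 h (on this read-out lower numbers stand for stronger inhibition and higher numbers for weaker inhibition), compound 1 `COC[C@H](C(C)C)C(c1ccc(O)c(OC)c1)c1ccc(O)c(OC)c1` gives 76000 nM. Compound 3 `COC[C@H](C)[C@@H](C)C(c1ccc(O)c(OC)c1)c1ccc(O)c(OC)c1` gives 77000 nM in this assay; the two values lie within the scatter of each other, as a 1.0-fold higher number from compound 1 to compound 3 (0.01 log units; within the scatter) shows. Compound 2 `COc1cc(C(c2ccc(O)c(OC)c2)[C@H](C)[C@H](C)CO)ccc1O` reaches only a limit in this assay, > 100000 nM, and so has no number of its own. It stands at the limit of > 100000 nM in this assay, at which 1 of the 3 values shown sits. The steps involving it read an at least 1.3-fold higher number from compound 1 to compound 2 (0.11 log units; that floor lies within the scatter) and an at least 1.2-fold lower number from compound 2 to compound 3 (0.11 log units; that floor lies within the scatter); the second of these is the change of hydroxymethyl to methoxymethyl, and its floor lies within the scatter.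

Compound 4 `COC[C@@H](C)[C@@H](C)C(c1ccc(O)c(OC)c1)c1ccc(O)c(OC)c1` has not yet been measured in this assay. It differs from compound 2 by methyl in place of hydrogen on an oxygen on a saturated carbon. Within the data shown here, the only measured step that bears on this change is the one from the hydroxymethyl compound to its methoxymethyl partner, whose floor was within the scatter, and the two methoxymethyl compounds measured so far, compound 1 and compound 3, sit within the scatter of each other. The change is therefore expected to give an at least 1.2-fold lower number from compound 2 to compound 4 (0.11 log units; that floor lies within the scatter), a move down from the limit no larger than what the scatter can carry. Compound 4 is estimated at 77000 nM, with a range from 40000 nM to 150000 nM.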

Compound 4, half-maximal inhibitory concentration: > 100000 nM
Compound 4: a limit, no number; the forecaster's own chance of this, stated with the estimate: 30%; at least 1.2-fold (0.11 log units) between middle value and limit.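

Working notes, continued. In this assay the methyl on the oxygen does not by itself lift a compound off the limit, and the step from compound 2 to compound 4 cannot be read with a limit on each side, so hydroxymethyl to methoxymethyl on this chain has no measured size here, and compound 4 shares the limit of compound 2: the limit of > 100000 nM in this assay, at which 2 of the 4 values shown sit.

The methoxymethyl compounds now divide, with an at least 1.2-fold higher number from compound 3 to compound 4 (0.11 log units; that floor lies within the scatter) and an at least 1.3-fold higher number from compound 1 to compound 4 (0.11 log units; that floor lies within the scatter), yet both floors lie within the scatter, so a single change of configuration is not shown to matter in the pair that isolates it: the fact that compounds 3 and 4 differ only in the configuration as drawn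

What is new is therefore only that a methoxymethyl chain can also sit at the limit, so the earlier reading of compound 1 and compound 3 as a shared level does not extend to every stereoisomer.

On these data alone, whether compound 4 lies far from compound 3 or close to it stays open, as does the size of any effect of configuration at this carbon. Also open, as far as these compounds go, is how the series would read with an amine or a carboxylic acid in place of the methoxy group, or with a longer chain such as ethoxymethyl.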